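Cyano in Place of Phenoxy on an Amide Aryl Ring

This account rests on a few compounds, and the source may have more. Where it says the series, first, only, none or still open, it means among the compounds named here.

Measured compounds:
compound 1, `O=C(c1ccc(Cl)c(C(F)(F)F)c1)N1CCC(n2cncc2-c2ccc(OS(=O)(=O)c3cccc(Br)c3)cc2)CC1`, 896 nM
compound 2, `O=C(c1ccc(Oc2ccccc2)cc1)N1CCC(n2cncc2-c2ccc(OS(=O)(=O)c3cccc4cnccc34)cc2)CC1`, 187 nM

Of the compounds shown here, two sharing a piperidinyl-imidazole core have been measured in an assay on HEK293 cells for antagonist activity at P2X purinoceptor 7 (Homo sapiens), read by fluorescence, with a stated time of 2 h; a lower number here means a stronger inhibitor, a higher number a weaker inhibitor. Compound 1 gives 896 nM, and compound 2 gives 187 nM, the lower of the two numbers by a gap that lies beyond the usual scatter. The two differ in more than one place, so nothing can be said about any single change between them.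

Compound 3, `N#Cc1ccc(C(=O)N2CCC(n3cncc3-c3ccc(OS(=O)(=O)c4cccc5cnccc45)cc3)CC2)cc1`, has not been measured. It differs from compound 2 in one place: cyano in place of phenoxy on an aromatic carbon. No measured pair shows this exchange, so the account can only reason from compound 2 itself. Since compound 2 stands at 187 nM, the expectation is a step from compound 2 to compound 3 of a 2.1-fold higher number from compound 2 to compound 3 (0.33 log units; beyond the scatter) toward a somewhat higher number, though a result within the scatter would not surprise. The estimated value for compound 3 is 400 nM, with a plausible range from 150 nM to 1200 nM.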

Compound 3, half-maximal inhibitory concentration: 269 nM
The estimate for compound 3 lay 1.5-fold (0.17 log units) above the measured number; measured number inside the range.
By their numbers in this assay, from the lowest: compounds 2 and 3 (each within the scatter of the next); then compound 1.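

Going by these compounds alone, the new pair is the first reading of a single change at this position, on an aromatic carbon para to a large group of the amide aryl ring. In this assay the exchange of phenoxy for cyano gives a 1.4-fold higher number from compound 2 to compound 3 (0.16 log units; within the scatter), so the two numbers cannot be told apart even though the group that leaves has 7 heavy atoms and a six-membered aromatic ring of carbon only, while the group that enters has 2 heavy atoms and no ring. At this position, with the rest of the molecule held fixed, the terminal aromatic ring of phenoxy is therefore not required to keep the number within the scatter, and both groups count 1 hydrogen-bond acceptor and no donor. Nothing available here explains this result.

The compounds shown leave open what a carboxylic acid, an amine or a longer chain would give on the same aromatic carbon, and whether a group without a hydrogen-bond acceptor, such as methyl, would give a similar number. They also leave open whether the same exchange would behave alike with a different group on the sulfonate ester.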